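The compounds below may be only part of what the source reports. "The series", "measured", "known", "first", "only" and "open" are said of these compounds alone.

Measured so far:
- compound 1, `COc1cc2c(Oc3ccc(NC(=O)c4nc(-c5ccc(F)cc5)no4)cc3)ccnc2cc1OCCCN1CCC(C)CC1`: 870 nM
- compound 2, `COc1cc2c(Oc3ccc(NC(=O)C4(c5nnc(-c6ccc(F)cc6)o5)CC4)cc3F)ccnc2cc1OCCCN1CCCC1`: 150 nM

In a functional assay on A549 cells (Homo sapiens) for antiproliferative activity, read by MTT assay, with a stated time of 72 h (on this read-out lower numbers stand for stronger inhibition and higher numbers for weaker inhibition), compound 1 gives 870 nM, the highest of the two numbers; in the same assay compound 2 gives 150 nM, a lower number that lies beyond the usual scatter. Going by the values given here, no pair of measured compounds that differ in one place is available, so there is no direct step to read from compound 1.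

Compound 3, `COc1cc2c(Oc3ccc(NC(=O)c4nnc(-c5ccc(F)cc5)o4)cc3)ccnc2cc1OCCCN1CCC(C)CC1`, is still to be measured in this assay. It is built from the same atoms as compound 1, joined differently: 5-(4-fluorophenyl)-1,3,4-oxadiazol-2-yl in place of 3-(4-fluorophenyl)-1,2,4-oxadiazol-5-yl on a carbonyl carbon. The 5-(4-fluorophenyl)-1,3,4-oxadiazol-2-yl group replaces the 3-(4-fluorophenyl)-1,2,4-oxadiazol-5-yl group on the carbonyl carbon, which otherwise bears only the amide-type nitrogen. Among the compounds with values here, the data give no step for this exchange. The expectation is a small move, at most modest, toward a lower number, with no step beyond the scatter ruled out in either direction. For compound 3 the estimate is 600 nM, with a range from 250 nM to 1500 nM, which means an expected step of a 1.5-fold lower number from compound 1 to compound 3 (0.16 log units; within the scatter).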

Compound 3, half-maximal inhibitory concentration: 2730 nM
Compound 3: the middle estimate sits 4.6-fold (0.66 log units) below what was measured; measured number outside the range, above it.
By their numbers in this assay, from the lowest: compound 2; then compound 1; then compound 3.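

In this assay, going by these compounds alone, the exchange of 5-(4-fluorophenyl)-1,3,4-oxadiazol-2-yl for 3-(4-fluorophenyl)-1,2,4-oxadiazol-5-yl on a carbonyl carbon gives a 3.1-fold higher number from compound 1 to compound 3 (0.50 log units; beyond the scatter) and is the first one-place step. The two groups have the same heavy atoms, the same rings and the same counts of hydrogen-bond donors and acceptors, so these counts do not separate them, while the way the atoms are joined at this position does change the number beyond the scatter. No measurement at hand bears on the reason for this step.

Within the data shown here, compound 2 differs from compound 1 and from compound 3 in more than one place, so no step to compound 2 can be read, and this single exchange cannot be said to hold with the other features of compound 2. Also open, from the compounds shown here alone, is where a 5-(4-fluorophenyl)-1,3,4-thiadiazol-2-yl group, with sulfur in place of the ring oxygen, would fall on the same carbonyl carbon relative to the two oxadiazole groups.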